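Amide aryl swap on a thiourea-bearing thienopyridine core

This account rests on a few compounds, and the source may have more. Where it says the series, first, only, none or still open, it means among the compounds named here.

Compound 1, `NC(=O)c1c(NC(=O)c2cccc([N+](=O)[O-])c2)sc2c1CCN(Cc1c(Cl)cccc1Cl)C2`, gives 46100 nM in a functional assay on HeLa cells (Homo sapiens) for antiproliferative activity, with a stated time of 24 h; on this read-out lower numbers stand for stronger inhibition and higher numbers for weaker inhibition.
Compound 2, `NC(=O)c1c(NC(=O)c2ccccc2)sc2c1CCN(C(=S)Nc1ccccc1Cl)C2`, reaches only the limit of this assay at > 50000 nM.
Compound 3, `NC(=O)c1c(NC(=O)c2ccc(C(F)(F)F)cc2)sc2c1CCN(C(=S)Nc1ccccc1Cl)C2`, gives 44000 nM in this assay.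

Compound 3 holds the lowest of the two numbers shown, but its gap to compound 1 lies within the scatter, so no order between them can be claimed. For the measured compounds named here, the only single-point step measured, an at least 1.1-fold lower number from compound 2 to compound 3 (0.05 log units; that floor lies within the scatter), is small and rests on one side on the limit (the limit of > 50000 nM in this assay, at which 1 of the 3 values shown sits).

Compound 4, `NC(=O)c1c(NC(=O)c2cccc([N+](=O)[O-])c2)sc2c1CCN(C(=S)Nc1ccccc1Cl)C2`, differs from compound 3 by 3-nitrophenyl in place of 4-(trifluoromethyl)phenyl on a carbonyl carbon. Going by the values given here, no measured step covers this exact exchange; compound 1 carries the same 3-nitrophenyl amide with a different group on the ring nitrogen and sits beside compound 3. Compound 4 is therefore expected to stay within the scatter of compound 3, an expected step of a 1.1-fold higher number from compound 3 to compound 4 (0.04 log units; within the scatter). The estimate for compound 4 is 48000 nM, with a range from 25000 nM to 100000 nM, and a real chance that only a limit is reported.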

Compound 4, half-maximal inhibitory concentration: 40300 nM
Estimate against measurement, compound 4: 1.2-fold (0.08 log units) above, and the stated range covers the measured number.
By their numbers in this assay, from the lowest: compounds 4, 3 and 1 (each within the scatter of the next). At a limit, above all of these: compound 2.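

On the carbonyl carbon, 3-nitrophenyl and 4-(trifluoromethyl)phenyl cannot be told apart in this assay: the exchange gives a 1.1-fold lower number from compound 3 to compound 4 (0.04 log units; within the scatter). With the 3-nitrophenyl amide held fixed, the group on the amine nitrogen in a ring also makes no readable difference, with a 1.1-fold lower number from compound 1 to compound 4 (0.06 log units; within the scatter). Nitro in place of hydrogen on an aromatic carbon gives an at least 1.2-fold lower number from compound 2 to compound 4 (0.09 log units; that floor lies within the scatter), and this floor rests on the value of compound 2, which is a limit: the limit of > 50000 nM in this assay, at which 1 of the 4 values shown sits.

The compounds shown leave open whether an amine or a carboxylic acid on that aromatic ring, or a longer chain in its place on the carbonyl carbon, would give a number beyond the scatter of these values. They also leave open how far the number for compound 2 lies from the others.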